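Chain-end variation on the piperidine side of the series

This account rests on a few compounds, and the source may have more. Where it says the series, first, only, none or still open, it means among the compounds named here.

Compound 2 `COc1ccc2nccc(C3CN(C4CCN(CC5CCCCC5)CC4)C(=O)O3)c2c1` carries cyclohexyl on a saturated chain carbon bound to an amine nitrogen in a ring. In an in vitro functional assay on RBL cells for antagonist activity at C-C chemokine receptor type 8 (Homo sapiens), read by FLIPR and calcium flux (a higher number here means a weaker inhibitor, a lower number a stronger inhibitor), compound 2 gives 7940 nM, the highest of the two numbers available. Among the measured compounds shown here, its nearest neighbour is compound 1 `COc1ccc2nccc(C3CN(C4CCN(Cc5cc6ccccc6o5)CC4)C(=O)O3)c2c1`, which in this assay gives 1260 nM; the step of a 6.3-fold higher number from compound 1 to compound 2 (0.80 log units; beyond the scatter) is the only measured comparison, and it shows that exchanging 1-benzofuran-2-yl for cyclohexyl at this position weakened inhibition well beyond the scatter.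

Compound 3 `COc1ccc2nccc(C3CN(C4CCN(CCCc5ccccc5)CC4)C(=O)O3)c2c1` is the next point on the same chain. It differs from compound 2 in one place: phenethyl in place of cyclohexyl on a saturated chain carbon bound to an amine nitrogen in a ring. The change restores an aromatic ring at the chain end while lengthening the chain, and the same difference, cut one bond further out, reads cyclohexylmethyl to 3-phenylpropyl. For the measured compounds named here, only one measured step bears on compound 3; a decrease in this assay is expected for compound 3 because a 6.3-fold higher number from compound 1 to compound 2 (0.80 log units; beyond the scatter) points to an aromatic ring at this position being favoured. The ring entering is plain phenyl, on a longer chain, and the expected step is taken smaller than that measured one. For compound 3 the estimated step is a 2.5-fold lower number from compound 2 to compound 3 (0.39 log units; beyond the scatter). Compound 3 is therefore expected at about 3200 nM, within 1000 nM to 10000 nM.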

Compound 3, half-maximal inhibitory concentration: 251 nM
Compound 3: the middle estimate sits 13-fold (1.11 log units) above what was measured, and the stated range ends above it.
By their numbers in this assay, from the lowest: compound 3; then compound 1; then compound 2.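

In this assay, phenethyl in place of cyclohexyl on a saturated chain carbon bound to an amine nitrogen in a ring gives a 32-fold lower number from compound 2 to compound 3 (1.50 log units; beyond the scatter), so this position tolerates far more than the first pair suggested and responds strongly to what sits at the chain end. Among the compounds shown here, the fused 1-benzofuran-2-yl is also not required for the best number so far: a single six-membered aromatic ring of carbon on the longer chain goes further, with a 5.0-fold lower number from compound 1 to compound 3 (0.70 log units; beyond the scatter). No measurement on hand explains either step.

Ring type and chain length change together in both new steps, so the three compounds cannot say how much of the gain belongs to the aromatic ring and how much to the longer chain. A 3-cyclohexylpropyl group on the same nitrogen would address the ring, benzyl or a 4-phenylbutyl chain would address the length, and substituents on the phenyl ring, such as a methoxy group or a fluorine, remain an open question at this chain end.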